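A few compounds are considered here, and "the series" means these few. Any claim that something is new, unique, unknown or untested is made for them only; others in the source may bear on it.

Measured compounds:
Compound 1 `CCCCCCCCCCNC(=O)C1C(C(=O)O)[C@@H]2CC[C@H]1O2`: 10000 nM
Compound 2 `Cc1cc(C)c(NC(=O)C2C(C(=O)O)[C@@H]3CC[C@H]2O3)c(C)c1`: 10000 nM
Compound 3 `CCOC(=O)c1cn[nH]c1NC(=O)C1C(C(=O)O)[C@@H]2CC[C@H]1O2`: 10000 nM

In an ADME assay on DU-145 cells (Homo sapiens) for cytotoxicity, read by MTT assay, with a stated time of 72 h (a lower number here means a stronger inhibitor of growth, a higher number a weaker inhibitor of growth), compound 1 gives 10000 nM, which puts it level with compound 2 and compound 3. The three share a core but carry quite different groups on its amide, and their numbers do not separate them. No two of them differ in only one place, so the effect of a single change has not yet been measured.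

Compound 4 `CCCCNC(=O)C1C(C(=O)O)[C@@H]2CC[C@H]1O2` has not been measured. Its difference from compound 1 is hydrogen in place of hexyl on a saturated chain carbon, four bonds along the chain from an amide-type nitrogen. In words, this is hydrogen in place of hexyl on a saturated chain carbon, four bonds along the chain from an amide-type nitrogen.

No step beyond the scatter is expected in this assay, since compound 2 gives 10000 nM and compound 3 gives 10000 nM despite their very different groups. The expected no change at the digits printed from compound 1 to compound 4 (within the scatter) is therefore small. For compound 4 the estimated value is 10000 nM, with an expected range from 5000 nM to 30000 nM.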

Compound 4, concentration for 50% growth inhibition: 10000 nM
For compound 4 middle estimate and measured number coincide at the digits printed; the range from low to high includes it.
By their numbers in this assay, from the lowest: compounds 1, 2, 3 and 4 (each within the scatter of the next).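

In this assay, going by these compounds alone, this pair gives the first reading of a single change: with hydrogen in place of hexyl on a saturated chain carbon, four bonds along the chain from an amide-type nitrogen, the result is no change at the digits printed from compound 1 to compound 4 (within the scatter) and the two compounds cannot be told apart. Within the data shown here, the earlier compounds showed only that quite different amide groups shared one number, whereas this step ties the comparison to one position and shows that the hexyl group makes no difference there that this assay can detect. No separate measurement is available to explain this result.

As far as these compounds go, it remains open whether an amine or a chain longer than that of compound 1 at this position would separate from compound 4 in this assay. The compounds shown also leave open whether any change to the shared core would give a different number.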